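From bromo to nitro to a difluorophenyl compound

The compounds below may be only part of what the source reports. "The series", "measured", "known", "first", "only" and "open" are said of these compounds alone.

So far, three compounds sharing one core have been measured in a functional assay on K562 cells (Homo sapiens) for cytotoxicity, read by MTT assay, with a stated time of 48 h; a lower number here means a stronger inhibitor, a higher number a weaker inhibitor. Compound 1 `COc1cc(-n2c(-c3ccc(Br)cc3)cn(C(C)=O)c2=O)cc(OC)c1OC` gives 1000 nM with a bromo group on its outer aromatic ring. Compound 2 `COc1cc(-n2c(-c3ccc(Cl)cc3)cn(C(C)=O)c2=O)cc(OC)c1OC` has chloro there and gives > 50000 nM as a limit of the assay and not a number. Compound 3 `COc1cc(-n2c(-c3ccc([N+](=O)[O-])cc3)cn(C(C)=O)c2=O)cc(OC)c1OC` has nitro there and gives 26600 nM as the higher of the two true numbers. Going from bromo, the data show an at least 50-fold higher number from compound 1 to compound 2 (1.69 log units; beyond the scatter) for chloro and a 27-fold higher number from compound 1 to compound 3 (1.42 log units; beyond the scatter) for nitro. Nitro and chloro show an at least 1.8-fold lower number from compound 2 to compound 3 (0.27 log units; that floor lies within the scatter) and so cannot be ranked. Compound 4 `COc1cc(-n2c(-c3ccc(F)cc3F)cn(C(C)=O)c2=O)cc(OC)c1OC` brings 2,4-difluorophenyl in place of 4-nitrophenyl on an aromatic carbon with the rest of the core unchanged. Like compound 3, it lacks the bromo of compound 1, and a 27-fold higher number from compound 1 to compound 3 (1.42 log units; beyond the scatter) is what that loss cost compound 3 here. So no step beyond the scatter is expected, with the estimate being a 1.1-fold higher number from compound 3 to compound 4 (0.05 log units; within the scatter) in this assay overall. Compound 4 is estimated at 30000 nM (range 8000 nM to 80000 nM).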

Compound 4, half-maximal inhibitory concentration: > 50000 nM
Compound 4: only a limit was reported (the forecaster's own chance of this, stated with the estimate: 40%); at least 1.6-fold (0.22 log units) between middle value and limit.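

In this assay compound 4 gives > 50000 nM, which is a limit of the assay and not a number. With an at least 50-fold higher number from compound 1 to compound 4 (1.69 log units; beyond the scatter), a third replacement for the 4-bromophenyl group at this position now falls far short of compound 1, so that group stands alone among the four shown. The other readable step, an at least 1.8-fold higher number from compound 3 to compound 4 (0.27 log units; that floor lies within the scatter), does not rank 2,4-difluorophenyl against 4-nitrophenyl, and the step between compound 2 and compound 4 cannot be read, because both stop at the same ceiling: the limit of > 50000 nM in this assay, at which 2 of the 4 values shown sit.

Still open, going by these compounds, is whether the activity of compound 1 belongs to bromo alone or would return with an iodo group, a methyl group or an amine on the same ring. On these data alone, how far compound 2 and compound 4 truly lie beyond the limit also stays unknown.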